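A few compounds are considered here, and "the series" means these few. Any claim that something is new, unique, unknown or untested is made for them only; others in the source may bear on it.

Compound 3, `O=S(=O)(Nc1ccc(-c2nc3ccccc3o2)cc1)c1ccccc1C(F)(F)F`, stands at the ceiling of an ADME assay on HEK293 cells (Homo sapiens) for cytotoxicity, read by resazurin assay, with a stated time of 48 h; on this read-out higher numbers stand for lower toxicity in this test and lower numbers for higher toxicity in this test: it gives > 100000 nM, which is a limit of the assay and not a number. Compound 1, `COc1ccc(S(=O)(=O)Nc2ccc(-c3nc4ccccc4o3)cc2)cc1`, gives > 100000 nM, also a limit. Compound 2, `O=S(=O)(Nc1ccc(-c2nc3ccccc3o2)cc1)c1cccc(Cl)c1`, gives > 100000 nM, again a limit. The step that the two limits leave unreadable from compound 1 to compound 2 therefore cannot be read, and the limit of > 100000 nM in this assay, at which 3 of the 3 values shown sit, is all that the numbers show. Compound 4 is `O=S(=O)(Nc1ccc(-c2nc3ccccc3o2)cc1)c1ccccc1O`; its change from compound 3 is hydroxy in place of trifluoromethyl on an aromatic carbon. Among the compounds with values here, no measured step bears on this change, so the only expectation rests on the limit of > 100000 nM in this assay, at which 3 of the 3 values shown sit: no step beyond the scatter. The expected step is a step that the limit leaves unreadable from compound 3 to compound 4. Compound 4 is thus estimated at 150000 nM, within a range from 50000 nM to 400000 nM, and will most likely again be reported only as a limit.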

Compound 4, half-maximal cytotoxic concentration: > 100000 nM
Compound 4 gave a limit, no number; the forecaster's own chance of this, stated with the estimate: 85%; the middle value is on the limit's open side.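

Compound 4, like compound 1, compound 2 and compound 3, gives only a limit in this assay, so none of the steps between them can be read: the limit of > 100000 nM in this assay, at which 4 of the 4 values shown sit.

From the compounds shown here alone, what stays open is the concentration at which any of these four compounds would reach the half-maximal cytotoxic level, and how they rank against one another.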